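This account rests on a few compounds, and the source may have more. Where it says the series, first, only, none or still open, it means among the compounds named here.

In an ADME assay for pharmacokinetics, read by LC-MS, in phosphate buffer, with a stated time of 120 min, at pH 7.4, tested at 1 uM, in the presence of a further agent that is not named here (a lower number here means that the compound disappears faster, a higher number that the compound lasts longer), compound 1 `O=C(/C=C/CF)Nc1ccccc1` gives > 8.53 h, which is a limit of the assay and not a number. Compound 2 `C=C(C)C(=O)Nc1ccccc1` gives > 8.53 h, which is also only a limit. Among the compounds with values here, the one measured step, a step that the two limits leave unreadable from compound 1 to compound 2, therefore has no size that can be used. Compound 3 `C=C(CN(C)C)C(=O)Nc1ccccc1` differs from compound 2 by dimethylamino in place of hydrogen on a saturated chain carbon bound to a double-bonded chain carbon: methyl becomes (dimethylamino)methyl. With no readable step to lean on, only a modest shortening of the half-life is expected, and this assay may report a limit again. The estimated change is an at least 1.4-fold lower number from compound 2 to compound 3 (0.15 log units; that floor lies within the scatter). For compound 3 the estimated half-life is 6 h, with an expected range of 1 h to 12 h.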

Compound 3, half-life: < 0.0334 h
Compound 3: a limit, no number (the forecaster's own chance of this, stated with the estimate: 45%); middle value at least 170-fold (2.25 log units) away from the limit.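

At this place, on a saturated chain carbon bound to a double-bonded chain carbon, dimethylamino in place of hydrogen gives an at least 250-fold lower number from compound 2 to compound 3 (2.40 log units; beyond the scatter) in this assay. This is the first step shown with a readable size, as the earlier step cannot be read. Both values behind it are limits of the assay, so the step sets a minimum size and gives no exact figure.

Still open, going by these compounds, is whether this drop needs the nitrogen of dimethylamino, or whether a methoxy group or a longer carbon chain on the same carbon would give the same result.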